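Phenyl replacing 4-chloro-3-(trifluoromethyl)phenyl: what compound 4 may show

This account rests on a few compounds, and the source may have more. Where it says the series, first, only, none or still open, it means among the compounds named here.

The measured compounds in a functional assay on HOP-62 cells (Homo sapiens) for inhibition, read by sulforhodamine B assay, with a stated time of 48 h; a lower number here means that less compound is tolerated, a higher number that more compound is tolerated:
compound 1 `O=C(Nc1cccc(-n2cc(-c3ccncc3)c(-c3ccc(Cl)c(O)c3)n2)c1)Nc1ccc(Cl)c(Cl)c1` gives > 32500 nM, which is a limit of the assay.
compound 2 `COc1cc(-c2nn(-c3cccc(NC(=O)Nc4cccc(C(F)(F)F)c4)c3)cc2-c2ccncc2)ccc1Cl` gives > 50000 nM, also a limit.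
compound 3 `COc1cc(-c2nn(-c3cccc(NC(=O)c4ccc(Cl)c(C(F)(F)F)c4)c3)cc2-c2ccncc2)ccc1Cl` gives > 32500 nM, again a limit.

Compound 3 thus stands at a limit and not at a number, as do the other two values shown: two sit at the limit of > 32500 nM in this assay, at which 2 of the 3 values shown sit, and one at the limit of > 50000 nM in this assay, at which 1 of the 3 values shown sits. Going by the values given here, the only measured step that changes one place, a step that the two limits leave unreadable from compound 2 to compound 3, is unreadable between the two limits, so no measured step gives a readable size.

Compound 4 `COc1cc(-c2nn(-c3cccc(NC(=O)c4ccccc4)c3)cc2-c2ccncc2)ccc1Cl` differs from compound 3 by phenyl in place of 4-chloro-3-(trifluoromethyl)phenyl on a carbonyl carbon. Since every value shown is a limit, no direction or size can be drawn from them for this change. The expectation for compound 4 is therefore that it, too, remains at a limit in this assay, with an estimated step that the limit leaves unreadable from compound 3 to compound 4 that cannot exceed the scatter in any readable way. Compound 4 is expected to give about 40000 nM, within 15000 nM to 100000 nM.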

Compound 4, concentration lethal to 50% of the cells: > 100000 nM
Compound 4: no number, only a limit; the forecaster's own chance of this, stated with the estimate: 80%; middle value at least 2.5-fold (0.39 log units) away from the limit.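

In this assay compound 4 gives > 100000 nM, which is a limit of the assay and not a number. Its steps from compound 2 and from compound 3 cannot be read, as all three values are limits. The compounds shown leave open whether changing the group on the carbonyl carbon alters the read-out at all.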